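The source may report more compounds than this note shows. Statements on the series, on what has been measured and on what is new or still open speak of the compounds shown alone.

The series shares the core of compound 1 `CCN(CC)C1CCC(COCc2cc(C(F)(F)F)cc(C(F)(F)F)c2)(c2ccccc2)CC1`, which carries a diethylamino group. Going by the values given here, in an assay on isolated protein for antagonist activity at Substance-P receptor (Homo sapiens) (a lower number here means a stronger inhibitor, a higher number a weaker inhibitor), compound 1 gives 38 nM, the highest of the two numbers measured so far. Compound 2 `CN(C)C1CCC(COCc2cc(C(F)(F)F)cc(C(F)(F)F)c2)(c2ccccc2)C1` is the nearest neighbour; in this assay compound 2 gives 8 nM, a lower number by a margin beyond the scatter, but compound 2 differs from compound 1 in more than one place, so no single step can be read from that pair.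

Compound 3 `CCNC1CCC(COCc2cc(C(F)(F)F)cc(C(F)(F)F)c2)(c2ccccc2)CC1` is the next case. It differs from compound 1 in one place: hydrogen in place of ethyl on an amine nitrogen. No measured pair in the series isolates this change, so the direction rests on judgement rather than on a shown step. The expected step is a 1.5-fold lower number from compound 1 to compound 3 (0.18 log units; within the scatter), small and possibly within the scatter, with a slight lean toward a lower number. For compound 3 the expected value in this assay is 25 nM, with a range from 8 nM to 80 nM.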

Compound 3, half-maximal inhibitory concentration: 14 nM
Compound 3: the middle estimate sits 1.8-fold (0.25 log units) above what was measured; the measured number falls inside the stated range.
By their numbers in this assay, from the lowest: compounds 2 and 3 (each within the scatter of the next); then compound 1.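

In this assay, going by these compounds alone, the change from diethylamino to ethylamino gives a 2.7-fold lower number from compound 1 to compound 3 (0.43 log units; beyond the scatter) and so provides the only step that isolates a single place. The earlier values could not show this, since compound 1 and compound 2 differ in more than one place. On this amine nitrogen, one ethyl can be replaced by hydrogen without loss of inhibition at the Substance-P receptor, and the modest step, which lies beyond the scatter, runs towards a stronger inhibitor. Nothing available on these compounds accounts for the step, which stands as an observation on one pair.

As far as these compounds go, it remains open whether the direction holds when the remaining ethyl is also replaced by hydrogen to give the primary amine on the shared core, and whether a methyl or a longer chain such as propyl on the same nitrogen follows compound 3 or compound 1. Also open, from the compounds shown here alone, is whether the same replacement of ethyl by hydrogen gives a step of similar size in a second matched pair.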